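The compounds below may be only part of what the source reports. "The series", "measured", "known", "first", "only" and "open" are said of these compounds alone.

Measured so far in a functional assay on ACHN cells (Homo sapiens) for cytotoxicity, read by sulforhodamine B assay, with a stated time of 72 h; on this read-out lower numbers stand for stronger inhibition of growth and higher numbers for weaker inhibition of growth:

- compound 1, `O=C(Nc1cc(C(F)(F)F)cc(C(F)(F)F)c1)C1CCc2ccccc2N1C(=O)c1ccc(Cl)cc1`: 2570 nM
- compound 2, `O=C(Nc1cc(C(F)(F)F)cc(C(F)(F)F)c1)C1CCc2ccccc2N1C(=O)c1ccccc1Cl`: 4700 nM
- compound 3, `O=C(Nc1ccccc1O)C1CCc2ccccc2N1C(=O)c1cccc(Cl)c1`: 17200 nM

Compound 2 stands second highest of the three numbers. Its nearest neighbour is compound 1, and the step of a 1.8-fold higher number from compound 1 to compound 2 (0.26 log units; within the scatter) lies within the scatter, so the two cannot be told apart. For the measured compounds named here, compound 3 gives a number well beyond the scatter from compound 2, but it differs from compound 2 in two places, so no single step is drawn between them.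

Compound 4, `CCCCCCCCC(=O)N1c2ccccc2CCC1C(=O)Nc1cc(C(F)(F)F)cc(C(F)(F)F)c1`, is not yet measured. It differs from compound 2 in one place: octyl in place of 2-chlorophenyl on a carbonyl carbon. Going by the values given here, no measured step bears on this change; the only step on record swaps one chlorophenyl for another on the same carbonyl carbon and stays within the scatter. With an aromatic ring giving way to an eight-carbon chain, there is no guide in the numbers, so the expectation is broad. Compound 4 is expected to give about 6000 nM, within a range of 2000 nM to 20000 nM. This estimate means a step of a 1.3-fold higher number from compound 2 to compound 4 (0.11 log units; within the scatter), expected to be modest and possibly within the scatter.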

Compound 4, concentration for 50% growth inhibition: 4520 nM
Compound 4: middle estimate off by 1.3-fold (0.12 log units), on the high side; measured number inside the range.
By their numbers in this assay, from the lowest: compounds 1, 4 and 2 (each within the scatter of the next); then compound 3.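

In this assay, the swap at this carbonyl carbon is now much larger than one chlorophenyl for another, yet the result stays within the scatter: a 1.0-fold lower number from compound 2 to compound 4 (0.02 log units; within the scatter), and a 1.8-fold higher number from compound 1 to compound 4 (0.25 log units; within the scatter). Compound 1, compound 2 and compound 4 cannot be told apart, so among these three, an aromatic ring on this carbonyl carbon is not required for growth inhibition at this level, and an octyl chain with no ring serves as well. Nothing measured here explains why a ring and a chain read alike at this place.

The compounds shown leave open how much the length of the chain matters, as with a shorter ethyl or a longer dodecyl group. They also leave open whether an amine or a carboxylic acid at the end of the octyl chain would be accepted at this carbonyl carbon.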